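Chloro for fluoro on a nitrogen-bound phenyl ring

The source may report more compounds than this note shows. Statements on the series, on what has been measured and on what is new or still open speak of the compounds shown alone.

Three compounds share one core and differ only in the substituted phenyl ring carried on an aromatic nitrogen. Compound 1 `Oc1cc(C(F)(F)F)ccc1-c1nc(-c2ccccc2O)n(-c2ccccc2F)n1` carries a 2-fluorophenyl group there, and in a functional assay on PC-12 cells (Rattus norvegicus) for cytotoxicity, read by MTT assay, with stated times of 2 h and 24 h, tested at 1 uM (on this read-out lower numbers stand for a weaker effect and higher numbers for a stronger effect at the one concentration tested), compound 1 gives 63.4%. Compound 2 `Oc1cc(C(F)(F)F)ccc1-c1nc(-c2ccccc2O)n(-c2ccccc2Cl)n1` carries a 2-chlorophenyl group instead, and in this assay compound 2 gives 70.1%. The change between them is chloro in place of fluoro on an aromatic carbon, and it gave a number 6.7 percentage points higher from compound 1 to compound 2 (within the scatter). Compound 3 `Oc1cc(C(F)(F)F)ccc1-c1nc(-c2ccccc2O)n(-c2cccc(F)c2)n1` has the fluorine at another point on that ring; the difference from compound 1 is 3-fluorophenyl in place of 2-fluorophenyl on an aromatic nitrogen. In this assay compound 3 gives 67.2%. Both a number 3.8 percentage points higher from compound 1 to compound 3 (within the scatter) and a number 2.9 percentage points lower from compound 2 to compound 3 (within the scatter) are small, so the three numbers sit close together and none stands apart.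

Compound 4 `Oc1cc(C(F)(F)F)ccc1-c1nc(-c2ccccc2O)n(-c2cccc(Cl)c2)n1` has not yet been measured. It differs from compound 3 by chloro in place of fluoro on an aromatic carbon. Within the data shown here, this is the same kind of change as the one from compound 1 to compound 2, though not the same: in the earlier case the chlorine enters ortho to a large group, here it enters meta to a large group. Among the measured compounds shown here, for compound 4 the step expected is a number 3.8 percentage points higher from compound 3 to compound 4 (within the scatter), a small one, because the single earlier example of this kind of change gave a number 6.7 percentage points higher from compound 1 to compound 2 (within the scatter). The estimate for compound 4 in this assay is 71%, with the range 60% to 82% expected to cover most repeat measurements.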

Compound 4, a percentage reported as activity, at one concentration (the size of the read-out at that concentration, not a potency): 72.3%
Estimate against measurement, compound 4: 1.3 percentage points below; low and high end bracket the measured number.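

The new step, a number 5.1 percentage points higher from compound 3 to compound 4 (within the scatter), is the same swap of fluoro for chloro as the earlier one, now made on a second core, and in this assay the two readings agree: the same change on two cores in this assay, a number 6.7 percentage points higher (within the scatter) from compound 1 to compound 2 and a number 5.1 percentage points higher (within the scatter) from compound 3 to compound 4, 1.6 percentage points apart, within the scatter of two such steps. The two other new steps, a number 2.2 percentage points higher from compound 2 to compound 4 (within the scatter) and a number 8.9 percentage points higher from compound 1 to compound 4 (within the scatter), are just as small, so all four compounds sit close together and none stands apart. This shows that, in these two cases, the swap behaves alike on both cores, but each step is no larger than the differences seen between repeated measurements, so it does not show that chloro really shifts the read-out, and two examples cannot establish a rule for the rest of the series.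

Every compound shown carries a single fluoro or chloro on the phenyl ring, so the compounds leave open what a methoxy group, an amine or a carboxylic acid at that place would give. They also leave open whether the two hydroxyl groups and the trifluoromethyl group of the shared core matter for the read-out, and how these compounds would behave at any other concentration.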